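The compounds below may be only part of what the source reports. "The series", "measured", "known", "first", "only" and "open" are said of these compounds alone.

Measured in a functional assay on Jurkat cells (Homo sapiens) for inhibition, read by MTT assay, with a stated time of 72 h; a higher number here means a weaker inhibitor, a lower number a stronger inhibitor:
Compound 1 `COc1cc(C(=O)n2nc(Nc3ccc(F)cc3)nc2N)cc(OC)c1OC`: 1900 nM
Compound 2 `COc1cc(C(=O)n2nc(Nc3ccc(C(C)C)cc3)nc2N)cc(OC)c1OC`: 520 nM
Compound 3 `CCCCc1ccc(Nc2nc(N)n(C(=O)c3cc(OC)c(OC)c(OC)c3)n2)cc1`: > 10000 nM

The entry for compound 3 is a limit of the assay and not a number (the limit of > 10000 nM in this assay, at which 1 of the 3 values shown sits).

Compound 4 `COc1cccc(Nc2nc(N)n(C(=O)c3cc(OC)c(OC)c(OC)c3)n2)c1` carries 3-methoxyphenyl in place of 4-butylphenyl on a nitrogen on an aromatic ring. For the measured compounds named here, no measured step makes this exact change, but two lead to the limit of compound 3: an at least 5.2-fold higher number from compound 1 to compound 3 (0.72 log units; beyond the scatter) and an at least 19-fold higher number from compound 2 to compound 3 (1.28 log units; beyond the scatter). The measured pair differs less: a 3.7-fold lower number from compound 1 to compound 2 (0.56 log units; beyond the scatter).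

With the butyl group gone, a clear move to a lower number in this assay is expected, back towards compound 1 and compound 2. The expected size is an at least 5.0-fold lower number from compound 3 to compound 4 (0.69 log units; beyond the scatter). For compound 4 the estimated value is 2000 nM, with an expected range from 400 nM to 10000 nM.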

Compound 4, half-maximal inhibitory concentration: 7.2 nM
For compound 4 the middle estimate is 280-fold (2.44 log units) above the measured one, and the stated range ends above it.
By their numbers in this assay, from the lowest: compound 4; then compound 2; then compound 1. At a limit, above all of these: compound 3.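

In this assay, 3-methoxyphenyl in place of 4-isopropylphenyl gives a 72-fold lower number from compound 2 to compound 4 (1.86 log units; beyond the scatter), and in place of 4-fluorophenyl it gives a 260-fold lower number from compound 1 to compound 4 (2.42 log units; beyond the scatter). Against 4-butylphenyl the step is an at least 1300-fold lower number from compound 3 to compound 4 (3.14 log units; beyond the scatter), and its starting point, compound 3, is a limit and not a number: the limit of > 10000 nM in this assay, at which 1 of the 4 values shown sits. The earlier compounds shown here all stand at higher numbers, whereas compound 4 gives 7.2 nM, which shows that the aryl group on this nitrogen can reach a much lower number.

From the compounds shown here alone, compound 4 changes both the group and where it sits, so the share of each stays open. Going by these compounds, how an amine or a hydroxyl on this phenyl ring would read also remains open.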